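Replacing the ring nitrogen of compound 2 with carbon

The source may report more compounds than this note shows. Statements on the series, on what has been measured and on what is new or still open speak of the compounds shown alone.

Two compounds share a core and differ only in the aryl group attached to the carbonyl carbon. Compound 1 `COc1cccc2cc(C(=O)N[C@H](CCCNC(=N)N)C(=O)NCc3ccc(C(F)(F)F)cc3)oc12` gives 622 nM in a functional assay on HEK293 cells for antagonist activity at melanin-concentrating hormone receptor 1 (Homo sapiens); on this read-out higher numbers stand for weaker inhibition and lower numbers for stronger inhibition. Compound 2 `N=C(N)NCCC[C@@H](NC(=O)c1ccc2ccccc2n1)C(=O)NCc1ccc(C(F)(F)F)cc1` gives 904 nM in this assay; this is the higher of the two numbers, but the step of a 1.5-fold higher number from compound 1 to compound 2 (0.16 log units; within the scatter) lies within the scatter, so neither compound can be called weaker. Compound 3 `N=C(N)NCCC[C@@H](NC(=O)c1ccc2ccccc2c1)C(=O)NCc1ccc(C(F)(F)F)cc1` has not yet been measured. It differs from compound 2 by naphthalen-2-yl in place of quinolin-2-yl on a carbonyl carbon. Among the compounds with values here, the only measured step at this position, a 1.5-fold higher number from compound 1 to compound 2 (0.16 log units; within the scatter), was within the scatter, and no other pair shows what losing the ring nitrogen does here. The step expected from compound 2 to compound 3 is therefore small, a 1.1-fold higher number from compound 2 to compound 3 (0.04 log units; within the scatter), with no clear direction. For compound 3 the estimate in this assay is 1000 nM, likely within 300 nM to 3500 nM.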

Compound 3, half-maximal inhibitory concentration: 212 nM
Estimate against measurement, compound 3: 4.7-fold (0.67 log units) above, outside the stated range (below it).
By their numbers in this assay, from the lowest: compound 3; then compounds 1 and 2 (each within the scatter of the next).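

In this assay the group on the carbonyl carbon now shows a step beyond the scatter: naphthalen-2-yl in place of quinolin-2-yl gives a 4.3-fold lower number from compound 2 to compound 3 (0.63 log units; beyond the scatter), so exchanging one ring nitrogen for carbon, with the count of heavy atoms unchanged, is enough to move the number at this position. Naphthalen-2-yl in place of 7-methoxy-1-benzofuran-2-yl gives a 2.9-fold lower number from compound 1 to compound 3 (0.47 log units; beyond the scatter), so compound 3 stands apart from both other compounds, which lie within the scatter of each other. Nothing available accounts for the effect of losing the ring nitrogen. The compounds shown leave open whether a chlorine atom or an amine on the naphthalen-2-yl group would keep the lower number of compound 3. They also leave open whether a single phenyl ring on the carbonyl carbon would do the same.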